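The compounds below may be only part of what the source reports. "The series", "measured", "known", "first", "only" and "open" are said of these compounds alone.

In a functional assay on A549 cells (Homo sapiens) for inhibition, read by MTT assay, with a stated time of 24 h (on this read-out higher numbers stand for weaker inhibition and lower numbers for stronger inhibition), compound 1 `CC1(C)[C@H]2CC[C@]1(C)N(Cc1cn(-c3ccccc3Cl)nn1)C(=O)C2` gives 70 nM and compound 2 `CC1(C)[C@H]2CC[C@]1(C)N(Cc1cn(-c3ccc(Br)cc3)nn1)C(=O)C2` gives 80 nM. Within the data shown here, compound 2 therefore stands level with compound 1, the only other measured compound, and the two values lie within the scatter of each other. Compound 3 `Cc1ccccc1-n1cc(CN2C(=O)C[C@@H]3CC[C@@]2(C)C3(C)C)nn1` differs from compound 2 by 2-methylphenyl in place of 4-bromophenyl on an aromatic nitrogen. Among the measured compounds shown here, one measured step bears on this change, since it altered the group at that same kind of nitrogen: a 1.1-fold higher number from compound 1 to compound 2 (0.06 log units; within the scatter), with 4-bromophenyl in place of 2-chlorophenyl. That single step is small, so no change beyond the scatter is expected in this assay. The expected step is a 1.1-fold lower number from compound 2 to compound 3 (0.03 log units; within the scatter). For compound 3 the estimated value is 75 nM, with an expected range of 35 nM to 160 nM.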

Compound 3, half-maximal inhibitory concentration: 90 nM
Compound 3: the middle estimate sits 1.2-fold (0.08 log units) below what was measured; low and high end bracket the measured number.
By their numbers in this assay, from the lowest: compounds 1, 2 and 3 (each within the scatter of the next).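

With a halogen-free 2-methylphenyl group on the aromatic nitrogen, the series still shows no step beyond the scatter in this assay: the exchange for 4-bromophenyl gives a 1.1-fold higher number from compound 2 to compound 3 (0.05 log units; within the scatter). Among these compounds, the first direct exchange at a single ring carbon, methyl in place of chloro, gives a 1.3-fold higher number from compound 1 to compound 3 (0.11 log units; within the scatter), so neither the halogen nor its replacement by methyl separates these compounds on this read-out. No measurement at hand offers an explanation for this flat result.

On these data alone, all three compounds carry a phenyl ring with one small substituent, so it remains open whether an amine or a carboxylic acid on that ring would shift the number beyond the scatter. Equally open, as far as these compounds go, is what a longer alkyl chain in place of the phenyl ring would do on the same nitrogen.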